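The source may hold more compounds than are shown below. What is called first, only, known or untested is meant among the compounds shown, and "the series" means these compounds.

Measured so far:
- compound 1 `COC(=O)C1=C(Nc2ccc(OC)cc2)O/C(=C\c2c[nH]c3ncccc23)C1=O`, which in an ADME assay on microsomes from liver (Rattus norvegicus) for metabolic stability, read by LC-MS, using NADPH, with a stated time of 30 min, tested at 1 uM (a lower number here means that less of the compound is left, a higher number that more of the compound is left), gives 5.1%
- compound 2 `COC(=O)C1=C(Nc2ccccc2F)O/C(=C\c2c[nH]c3ncccc23)C1=O`, which in this assay gives 10%

Both compounds share one core and differ only in the group carried on the amine nitrogen. Among the compounds with values here, on the numbers so far, compound 2 stands highest of the two, but its nearest neighbour, compound 1, lies within the usual scatter of the method: the one measured step, a number 4.9 percentage points higher from compound 1 to compound 2 (within the scatter), is too small to count as a real difference, so the two readings cannot be told apart.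

Compound 3 `COC(=O)C1=C(Nc2ccccc2C)O/C(=C\c2c[nH]c3ncccc23)C1=O` is the next compound. It differs from compound 2 by methyl in place of fluoro on an aromatic carbon. Within the data shown here, no measured step exchanges a fluoro for a methyl, so the only guidance is a number 4.9 percentage points higher from compound 1 to compound 2 (within the scatter), in which a different group on the same nitrogen was exchanged and the reading barely moved. On that basis a change no larger than the scatter is expected, and the step of no change at the digits printed from compound 2 to compound 3 (within the scatter) is estimated to stay within it. Compound 3 is therefore estimated to give 10% in this assay, expected to fall between 3% and 22%.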

Compound 3, percent of the compound remaining: 24%
Estimate against measurement, compound 3: 14 percentage points below; the measured number lies above the stated range.
By their numbers in this assay, from the lowest: compounds 1 and 2 (each within the scatter of the next); then compound 3.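

In this assay, within the data shown here, the exchange of fluoro for methyl on this aromatic carbon, ortho to a large group, gives the first step that clears the scatter: a number 14 percentage points higher from compound 2 to compound 3 (beyond the scatter), even though each group has a single heavy atom. The 2-methylphenyl group also stands apart from the 4-methoxyphenyl group, with a number 18.9 percentage points higher from compound 1 to compound 3 (beyond the scatter), so the earlier impression of a reading that barely responds to the group on the amine nitrogen does not hold for all three compounds, although both steps are modest and compound 3 gives only 24%. No measurement is available that bears on what lies behind this difference.

The compounds shown leave open how a chloro, an ethyl or a dimethylamino group would read on this same carbon, and so whether the higher number is particular to methyl. They also leave open how the reading would respond to a change in the shared core, such as a carboxylic acid in place of the methyl ester.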